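The source may hold more compounds than are shown below. What is called first, only, known or untested is meant among the compounds shown, and "the series" means these compounds.

Measured compounds:
- compound 1 `NC(=O)c1c(NC(=O)c2ccccc2Cl)sc2c1CCN(C(=S)Nc1ccccc1)C2` gives 46700 nM in a functional assay on HeLa cells (Homo sapiens) for antiproliferative activity, with a stated time of 24 h; on this read-out higher numbers stand for weaker inhibition and lower numbers for stronger inhibition
- compound 2 `NC(=O)c1c(NC(=O)c2ccccc2Cl)sc2c1CCN(C(=S)Nc1ccccc1F)C2` gives 28700 nM in this assay

Among the measured compounds shown here, compound 2 holds the lower of the two numbers so far, but its separation from compound 1 is only a 1.6-fold lower number from compound 1 to compound 2 (0.21 log units; within the scatter), a step that stays within the scatter, so the two compounds cannot be ranked against each other on this assay.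

The next compound, compound 3 `NC(=O)c1c(NC(=O)c2ccccc2Cl)sc2c1CCN(C(=S)Nc1c(Cl)cccc1Cl)C2`, is not yet measured. It differs from compound 2 in one place: 2,6-dichlorophenyl in place of 2-fluorophenyl on an amide-type nitrogen.

For the measured compounds named here, the only measured step that bears on this position is the one from compound 1 to compound 2, which also altered the phenyl ring on the amide-type nitrogen and produced a 1.6-fold lower number from compound 1 to compound 2 (0.21 log units; within the scatter), a change too small to read as real. Going by the values given here, no measured step tests a second halogen on that ring or chloro in place of fluoro. With that single, flat precedent, the expectation for compound 3 is a step of about a 1.1-fold lower number from compound 2 to compound 3 (0.06 log units; within the scatter), that is, nothing beyond the scatter in either direction.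

Compound 3 is therefore estimated at 25000 nM in this assay, with a range from 8000 nM to 80000 nM.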

Compound 3, half-maximal inhibitory concentration: 26500 nM
Compound 3: middle estimate off by 1.1-fold (0.03 log units), on the low side; the range from low to high includes it.
By their numbers in this assay, from the lowest: compounds 3, 2 and 1 (each within the scatter of the next).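

With 2,6-dichlorophenyl in place of 2-fluorophenyl on the amide-type nitrogen, this assay shows a 1.1-fold lower number from compound 2 to compound 3 (0.03 log units; within the scatter), so a second halogen and chloro in place of fluoro, both untested by the earlier pair, produce no readable change at this position. Measured against the plain phenyl of compound 1, 2,6-dichlorophenyl gives a 1.8-fold lower number from compound 1 to compound 3 (0.25 log units; within the scatter), so even with two chlorines on the ring the step stays within the scatter, and compound 1, compound 2 and compound 3 cannot be ranked against one another. Nothing available bears on why these three numbers stay together.

All the ring changes shown so far are halogens, so it remains open whether an amine, a carboxylic acid or a methoxy group on this phenyl ring would give a step beyond the scatter. Also open, as far as these compounds go, is whether a longer alkyl chain in place of the whole phenyl ring, or a carbonyl in place of the thiocarbonyl, would move the number in this assay.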